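Shortening the side chain on compound 1

A few compounds are considered here, and "the series" means these few. Any claim that something is new, unique, unknown or untested is made for them only; others in the source may bear on it.

Compound 1 `CCCCc1cnc(C(CCCC)Cc2ccc(-c3ccccc3C(=O)O)cc2)[nH]1` carries a butyl chain on the saturated carbon that joins its core to the rest of the molecule. In an in vitro functional assay on cells for agonist activity at Bombesin receptor subtype-3 (Homo sapiens), read by luminescence and calcium flux (on this read-out lower numbers stand for an effect already at smaller amounts and higher numbers for an effect only at larger amounts of compound), compound 1 gives 2660 nM, the higher of the two numbers recorded so far. Going by the values given here, the other measured member, compound 2 `O=C(O)c1ccccc1-c1ccc(CCc2ncc(CC3CCCCCC3)[nH]2)cc1`, gives 88 nM in this assay, and the gap to compound 1 lies well beyond the scatter, so compound 1 is the weaker of the pair; the two differ in several places at once, so no single-point step connects them.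

Compound 3 `CCCCc1cnc(C(CCC)Cc2ccc(-c3ccccc3C(=O)O)cc2)[nH]1` is the not yet measured neighbour of compound 1. The change is hydrogen in place of methyl on a saturated chain carbon, four bonds along the chain from an aromatic carbon, which read one bond further out is butyl to propyl. Among the compounds with values here, no measured pair isolates this kind of change, so its direction cannot be read from the series. Removal of a single chain carbon is expected to move the number little, most likely within the scatter or a slight rise, so the step from compound 1 to compound 3 is estimated at a 1.2-fold higher number from compound 1 to compound 3 (0.08 log units; within the scatter). Compound 3 is therefore expected to give about 3200 nM in this assay, within a range of 1100 nM to 9500 nM.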

Compound 3, half-maximal effective concentration: 1180 nM
Estimate against measurement, compound 3: 2.7-fold (0.43 log units) above; the measured number falls inside the stated range.
By their numbers in this assay, from the lowest: compound 2; then compound 3; then compound 1.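

Going by these compounds alone, this is the first single-point step: going from butyl to propyl on a saturated chain carbon, four bonds along the chain from an aromatic carbon, gives a 2.3-fold lower number from compound 1 to compound 3 (0.35 log units; beyond the scatter) in this assay on the shared core. The number at this position therefore responds to the loss of one chain carbon, and of the two chain lengths compared here, propyl gives the lower number, by a modest step that still lies beyond the scatter. The data give no explanation for this shift, and nothing measured alongside the assay bears on it.

As far as these compounds go, a single pair gives a direction for butyl to propyl only, so it remains open whether the number keeps falling with ethyl or methyl at this place, or whether it levels off or turns back up. Also open, from the compounds shown here alone, is how the position responds to a longer chain such as pentyl, to a cyclohexyl ring, or to a chain carrying a hydroxyl group or an amine.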